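Swapping a Hydroxy Tail for a Bromobutyl Chain

A few compounds are considered here, and "the series" means these few. Any claim that something is new, unique, unknown or untested is made for them only; others in the source may bear on it.

Of the compounds shown here, three have so far been tested in a functional assay on HL-60 cells (Homo sapiens) for cytotoxicity, read by MTT assay, with a stated time of 24 h; on this read-out higher numbers stand for weaker inhibition and lower numbers for stronger inhibition. Compound 1 `CC(C)(C)OC(=O)N1CCCN(CCCCCOc2c(Br)cc(Br)cc2Oc2ccc(Br)cc2Br)CC1` gives 44.8 ug/mL. Compound 2 `OCCOc1c(Br)cc(Br)cc1Oc1ccc(Br)cc1Br` gives 28.2 ug/mL. Compound 3 `Brc1ccc(Oc2cc(Br)cc(Br)c2OCCCCCN2CCN(C/C=C/c3ccccc3)CC2)c(Br)c1` gives 47.2 ug/mL. Compound 2 holds the lowest of the three numbers, yet its gaps to compound 1 and to compound 3 both lie within the usual scatter of this kind of measurement, so the three compounds are not clearly separated.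

Compound 4 `BrCCCCCCOc1c(Br)cc(Br)cc1Oc1ccc(Br)cc1Br` has not yet been measured. It differs from compound 2 in one place: 4-bromobutyl in place of hydroxy on a saturated chain carbon, two bonds along the chain from an oxygen on an aromatic ring. Within the data shown here, no pair of measured compounds shows a step of this kind, so there is no direct guide to its effect. Compound 4 is therefore expected to land near compound 2, with a step of a 1.1-fold lower number from compound 2 to compound 4 (0.04 log units; within the scatter) that stays within the scatter. The estimated value for compound 4 is 26 ug/mL, with a likely range from 10 ug/mL to 65 ug/mL.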

Compound 4, half-maximal inhibitory concentration: 37.8 ug/mL
Beside the measured number, compound 4's estimate is 1.5-fold (0.16 log units) below it; low and high end bracket the measured number.
By their numbers in this assay, from the lowest: compounds 2, 4, 1 and 3 (each within the scatter of the next).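

In this assay, putting 4-bromobutyl in place of hydroxy on this saturated chain carbon gives a 1.3-fold higher number from compound 2 to compound 4 (0.13 log units; within the scatter). At this position, then, the hydroxy group's hydrogen-bond donor and acceptor can leave and four carbons and a bromine can enter without a difference that this read-out can resolve. No other measurement here bears on this result. Still open, on these data alone, is whether a carboxylic acid or a nitrile in place of hydroxy at this carbon would separate clearly from compound 2.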